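The compounds below may be only part of what the source reports. "The series", "measured", "known", "first", "only" and "open" are said of these compounds alone.

Compound 2 `CC1=CC(C)(C)N(Cc2cn(Cc3cc4cc(C)ccc4nc3Cl)nn2)c2ccccc21` stands within the scatter of compound 1 `COc1ccc2c(c1)C(C)=CC(C)(C)N2Cc1cn(Cc2cc3cc(OC)ccc3nc2Cl)nn1` in a functional assay on HepG2 cells (Homo sapiens) for cytotoxicity, read by MTT assay, with a stated time of 48 h (on this read-out lower numbers stand for stronger inhibition and higher numbers for weaker inhibition), with compound 2 at 23000 nM and compound 1 at 27200 nM on this read-out. Compound 3 `COc1ccc2nc(Cl)c(Cn3cc(CN4c5ccccc5C(C)=CC4(C)C)nn3)cc2c1` differs from compound 2 by methoxy in place of methyl on an aromatic carbon. Within the data shown here, no measured step isolates this change. Among the measured compounds shown here, with compound 1 at 27200 nM and compound 2 at 23000 nM as the only values, no step beyond the scatter is expected in this assay here. The estimated 1.0-fold higher number from compound 2 to compound 3 (0.02 log units; within the scatter) stays small. Compound 3 is expected at 24000 nM with an estimated range of 10000 nM to 50000 nM for now.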

Compound 3, half-maximal inhibitory concentration: 41200 nM
Compound 3: the middle estimate sits 1.7-fold (0.23 log units) below what was measured; low and high end bracket the measured number.
By their numbers in this assay, from the lowest: compounds 2, 1 and 3 (each within the scatter of the next).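

In this assay, methoxy in place of methyl on this aromatic carbon gives a 1.8-fold higher number from compound 2 to compound 3 (0.25 log units; within the scatter) and so stays within the scatter. Hydrogen in place of methoxy on an aromatic carbon gives a 1.5-fold higher number from compound 1 to compound 3 (0.18 log units; within the scatter) and also stays within the scatter, so neither exchange separates these compounds on this read-out. No available evidence bears on these steps. Open, on these data alone, is whether an amine or a carboxylic acid on this aromatic carbon would give a step beyond the scatter in this assay or leave the number unmoved.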